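Swapping the alkyne-linked ring toward a chlorothiophene

The source may report more compounds than this note shows. Statements on the series, on what has been measured and on what is new or still open speak of the compounds shown alone.

Measured compounds:
compound 1 `O=C(O)COc1ccc(Cl)cc1C#Cc1ccncc1` — 601 nM
compound 2 `Cn1ccnc1C#Cc1cc(Cl)ccc1OCC(=O)O` — 1470 nM

In an assay on CHO cells for displacement of a labelled ligand from prostaglandin D2 receptor 2 (Homo sapiens), read by scintillation counting (a higher number here means a weaker inhibitor, a lower number a stronger inhibitor), compound 2 gives the higher of the two numbers, as the step of a 2.4-fold higher number from compound 1 to compound 2 (0.39 log units; beyond the scatter) shows. Compound 3 `O=C(O)COc1ccc(Cl)cc1C#Cc1ccc(Cl)s1` carries a further ring swap at the same place: 5-chlorothiophen-2-yl in place of 1-methyl-1H-imidazol-2-yl on a triple-bonded carbon. Going by the values given here, only that one step bears on it, and it was modest, so a step of similar size is expected here, its direction uncertain. Compound 3 is therefore estimated at 800 nM, within 250 nM to 2500 nM, an expected step of a 1.8-fold lower number from compound 2 to compound 3 (0.26 log units; within the scatter).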

Compound 3, inhibition constant: 183 nM
Compound 3: the middle estimate sits 4.4-fold (0.64 log units) above what was measured, and the stated range ends above it.
By their numbers in this assay, from the lowest: compound 3; then compound 1; then compound 2.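

With 5-chlorothiophen-2-yl on the triple-bonded carbon, this assay shows an 8.0-fold lower number from compound 2 to compound 3 (0.90 log units; beyond the scatter), and also a 3.3-fold lower number from compound 1 to compound 3 (0.52 log units; beyond the scatter). The ring at this place can therefore push the number down as well as up, and of these three rings the one with sulfur and chlorine gives the lowest number. Nothing measured here explains why this ring differs from the other two.

The compounds shown do not separate the part played by the thiophene ring from that of its chlorine. A plain thiophen-2-yl or a 4-chlorophenyl ring at this place would help to tell them apart.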